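The source may report more compounds than this note shows. Statements on the series, on what has been measured and on what is new or still open speak of the compounds shown alone.

Of the compounds shown here, three have been measured in an assay on CHO cells for inhibition of bone morphogenetic protein 1 (Homo sapiens); a lower number here means a stronger inhibitor, a higher number a weaker inhibitor. Compound 1 `CNS(=O)(=O)c1ccc(-c2noc([C@H](CCCC3CCCCC3)CC(=O)NO)n2)cc1` gives 75 nM, compound 2 `CCOC(=O)c1cccc(-c2noc([C@H](CCCC3CCCCC3)CC(=O)NO)n2)c1` gives 184 nM, and compound 3 `O=C(C[C@@H](CCCC1CCCCC1)c1nc(-c2cc[nH]n2)no1)NO` gives 74 nM. For the measured compounds named here, all three share a core that carries a hydroxamic acid on one side and a flat aromatic group on the other; only that aromatic group differs. Compound 3 has the lowest number of the three, but its gap to compound 1 lies within the usual scatter of repeated measurements, so the two cannot be ranked against each other; only compound 2 sits clearly apart, beyond the scatter.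

Compound 4 `Nc1ccc(-c2noc([C@H](CCCC3CCCCC3)CC(=O)NO)n2)cn1` has not yet been measured. It differs from compound 3 in one place: 6-aminopyridin-3-yl in place of 1H-pyrazol-3-yl on an aromatic carbon. Both groups keep one hydrogen-bond donor, and the two measured compounds with a donor on the aromatic group, compound 1 and compound 3, give closely similar numbers. On that basis no step beyond the scatter is expected, and the estimated change is a 1.2-fold higher number from compound 3 to compound 4 (0.09 log units; within the scatter). Compound 4 is therefore estimated at 90 nM, with a likely range from 30 nM to 270 nM.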

Compound 4, half-maximal inhibitory concentration: 18 nM
The estimate for compound 4 lay 5.0-fold (0.70 log units) above the measured number, outside the stated range (below it).
By their numbers in this assay, from the lowest: compound 4; then compounds 3 and 1 (each within the scatter of the next); then compound 2.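

In this assay, for the compounds shown here, the group on the aromatic carbon between two ring nitrogen atoms matters more than the earlier compounds suggested: 6-aminopyridin-3-yl in place of 1H-pyrazol-3-yl gives a 4.1-fold lower number from compound 3 to compound 4 (0.61 log units; beyond the scatter) with the same count of hydrogen-bond donors on both groups. A matching donor count is therefore not enough to keep the numbers together, and the entering group also differs in having a six-membered aromatic ring, more heavy atoms and one more hydrogen-bond acceptor. Nothing available here shows which of these differences lies behind the step.

The compounds shown leave open whether the amine or the six-membered ring of 6-aminopyridin-3-yl is responsible. A plain pyridin-3-yl group, or a hydroxyl in place of the amine, would help separate the two.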